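Ring Swap at the Aryl Amine: Sulfonyl Piperazine Expected

The source may hold more compounds than are shown below. What is called first, only, known or untested is meant among the compounds shown, and "the series" means these compounds.

Measured compounds:
Compound 1 `CC(O)(C#Cc1ccc(N2CCCC2)c(Nc2ncnc3[nH]ccc23)c1)c1nccs1` gives 107 nM.
Compound 2 `CCN1CCN(c2ccc(C#CC(C)(O)c3nccs3)cc2Nc2ncnc3[nH]ccc23)CC1` gives 34.5 nM.
Compound 3 `CN1CCCN(c2ccc(C#CC(C)(O)c3nccs3)cc2Nc2ncnc3[nH]ccc23)CC1` gives 60.1 nM.

These three share one core and differ only in the saturated nitrogen ring attached to an aromatic carbon. In an assay for inhibition of mitogen-activated protein kinase kinase kinase 14 (Homo sapiens), read by luminescence and ADP-Glo, with a stated time of 120 min, in the presence of a further agent that is not named here (a lower number here means a stronger inhibitor, a higher number a weaker inhibitor), compound 3 sits close to both of its neighbours: the step of a 1.8-fold lower number from compound 1 to compound 3 (0.25 log units; within the scatter) and the step of a 1.7-fold higher number from compound 2 to compound 3 (0.24 log units; within the scatter) are each within the scatter, so no ordering among the three can be claimed. Among the measured compounds shown here, the only step that is more than scatter is a 3.1-fold lower number from compound 1 to compound 2 (0.49 log units; beyond the scatter), and even that is modest.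

Compound 4 `CC(O)(C#Cc1ccc(N2CCN(S(=O)(=O)C3CC3)CC2)c(Nc2ncnc3[nH]ccc23)c1)c1nccs1` has not yet been measured. The change from compound 3 is 4-(cyclopropylsulfonyl)piperazin-1-yl in place of 4-methyl-1,4-diazepan-1-yl on an aromatic carbon. For the measured compounds named here, none of the measured steps tests a sulfonyl group here; they only show that exchanging one saturated nitrogen ring for another moves this assay little. On that basis the step of a 1.2-fold higher number from compound 3 to compound 4 (0.07 log units; within the scatter) is expected to stay within or near the scatter, with the direction uncertain. For compound 4 the estimate is 70 nM, between 25 nM and 200 nM.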

Compound 4, half-maximal inhibitory concentration: 16.2 nM
For compound 4 the middle estimate is 4.3-fold (0.64 log units) above the measured one; the whole stated range lies above it.
By their numbers in this assay, from the lowest: compound 4; then compounds 2, 3 and 1 (each within the scatter of the next, the first and the last beyond it).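

The earlier swaps of one saturated nitrogen ring for another left open whether this position could move the number much, and here a larger step appears: in this assay the new group gives a 3.7-fold lower number from compound 3 to compound 4 (0.57 log units; beyond the scatter) and also a 6.6-fold lower number from compound 1 to compound 4 (0.82 log units; beyond the scatter) as its biggest step, so compound 4 is the strongest inhibitor of the four. The cleanest comparison is with compound 2, which keeps the piperazine ring, and exchanging ethyl for cyclopropylsulfonyl on the ring's amine nitrogen gives a 2.1-fold lower number from compound 2 to compound 4 (0.33 log units; beyond the scatter) and shows that the group on that nitrogen alone can shift the result beyond the scatter, though only modestly. Nothing available here explains why the sulfonyl-bearing compound gives the lowest number.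

The compounds shown do not separate the sulfonyl part of the new group from its cyclopropyl part, which a methylsulfonyl or a cyclopropylcarbonyl group on the same ring nitrogen would begin to do. They also leave open whether cyclopropylsulfonyl would act in the same way on the seven-membered ring of 4-methyl-1,4-diazepan-1-yl, in place of its methyl.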